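From 2,4-dimethoxyphenyl to 2,5-dimethoxyphenyl on a shared core

This account rests on a few compounds, and the source may have more. Where it says the series, first, only, none or still open, it means among the compounds named here.

Among the compounds with values here, in a functional assay on K562 cells (Homo sapiens) for antiproliferative activity, read by MTT assay, with a stated time of 72 h (a higher number here means a weaker inhibitor, a lower number a stronger inhibitor), compound 1 `COc1cc(C(=O)c2sc3ccccc3c2-c2ccc(SC)cc2)cc(OC)c1OC` gives 1800 nM, while compound 2 `COc1ccc(-c2c(C(=O)c3cc(OC)c(OC)c(OC)c3)sc3ccccc23)c(OC)c1` gives 4100 nM, the higher and therefore the weaker of the two numbers known so far. Compound 3 `COc1ccc(OC)c(-c2c(C(=O)c3cc(OC)c(OC)c(OC)c3)sc3ccccc23)c1` keeps the shared core and carries 2,5-dimethoxyphenyl in place of 2,4-dimethoxyphenyl on an aromatic carbon. Within the data shown here, only one measured step bears on this change, a 2.3-fold higher number from compound 1 to compound 2 (0.36 log units; beyond the scatter), and it is modest. That step exchanged a different group, so it offers a rough size but no direction for the new change. A step of similar or smaller size is therefore expected in this assay, with no firm direction, and it may stay within the scatter. The expected step is a 1.2-fold lower number from compound 2 to compound 3 (0.07 log units; within the scatter). For compound 3 the estimated value is 3500 nM, with an expected range from 1400 nM to 9000 nM.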

Compound 3, half-maximal inhibitory concentration: > 10000 nM
Compound 3: only a limit was reported (the forecaster's own chance of this, stated with the estimate: 5%); middle value at least 2.8-fold (0.45 log units) from the limit.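

Compound 3 holds the same atoms as compound 2, yet exchanging 2,4-dimethoxyphenyl for 2,5-dimethoxyphenyl on this aromatic carbon gives an at least 2.4-fold higher number from compound 2 to compound 3 (0.38 log units; beyond the scatter) in this assay. The earlier pair changed the group itself, whereas this step shows that rearranging the same atoms within the group is enough to give a change beyond the scatter, and measured against 4-(methylsulfanyl)phenyl, the new group gives an at least 5.5-fold higher number from compound 1 to compound 3 (0.74 log units; beyond the scatter). Compound 3 gives only a limit of the assay, not a number, so both steps are minimum sizes: the limit of > 10000 nM in this assay, at which 1 of the 3 values shown sits.

The compounds shown do not tell how far the true value of compound 3 lies past that limit, or why the rearrangement matters. As far as these compounds go, it also remains open how a phenyl ring carrying a hydroxyl group or an amine in place of a methoxy group would behave at this position.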